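From an Aryl Limit to a Methylphenyl Analogue

The source may report more compounds than this note shows. Statements on the series, on what has been measured and on what is new or still open speak of the compounds shown alone.

Compound 1 `CCOC(=O)C1=Cc2ccccc2OC1(OCc1cn(CC(=O)Nc2cccc(Cl)c2)nn1)C(F)(F)F`: 12300 nM
Compound 2 `CCOC(=O)C1=Cc2ccccc2OC1(OCc1cn(-c2cccc(C(F)(F)F)c2)nn1)C(F)(F)F`: > 150000 nM

In a functional assay on HeLa cells (Homo sapiens) for inhibition, read by MTT assay, with a stated time of 24 h (a higher number here means a weaker inhibitor, a lower number a stronger inhibitor), compound 1 gives 12300 nM. For compound 2 the result is a limit of the assay, > 150000 nM (the limit of > 150000 nM in this assay, at which 1 of the 2 values shown sits). The step of an at least 12-fold higher number from compound 1 to compound 2 (1.08 log units; beyond the scatter) is thus known only as a bound on a large loss, and compound 2 stands at the limit rather than at a number.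

Compound 3 `CCOC(=O)C1=Cc2ccccc2OC1(OCc1cn(-c2ccc(C)cc2)nn1)C(F)(F)F` differs from compound 2 in one place: 4-methylphenyl in place of 3-(trifluoromethyl)phenyl on an aromatic nitrogen. For the measured compounds named here, only the step from compound 1 to compound 2 bears on this change, and it was large; it exchanged a carbamoylmethyl group for an aryl group, whereas compound 3 keeps an aryl group on the same nitrogen. Going by the values given here, no measured step compares one aryl with another. The expected step is therefore an at least 1.2-fold lower number from compound 2 to compound 3 (0.09 log units; that floor lies within the scatter), no larger than the scatter. Compound 3 is expected to give about 120000 nM, within 30000 nM to 400000 nM, with a fair chance of again returning only a limit.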

Compound 3, half-maximal inhibitory concentration: 25100 nM
Compound 3: the middle estimate sits 4.8-fold (0.68 log units) above what was measured; measured number outside the range, below it.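

In this assay, the aryl group on this aromatic nitrogen proves decisive: 4-methylphenyl in place of 3-(trifluoromethyl)phenyl gives an at least 5.9-fold lower number from compound 2 to compound 3 (0.77 log units; beyond the scatter). This step is known only as a bound, as the value for compound 2 is a limit: the limit of > 150000 nM in this assay, at which 1 of the 3 values shown sits. Against the ((3-chlorophenyl)carbamoyl)methyl group, 4-methylphenyl gives a 2.0-fold higher number from compound 1 to compound 3 (0.31 log units; beyond the scatter), so an aryl group at this position need not bring a loss as large as the one seen with 3-(trifluoromethyl)phenyl.

Compound 2 and compound 3 differ both in the group carried by the phenyl ring and in where it stands, so the compounds shown cannot separate these two changes. From the compounds shown here alone, what a 3-methylphenyl, a 4-(trifluoromethyl)phenyl or a 4-aminophenyl group would give on this nitrogen remains open.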